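Notes on the anilide group in the hydrazone series

A few compounds are considered here, and "the series" means these few. Any claim that something is new, unique, unknown or untested is made for them only; others in the source may bear on it.

Compound 1 `Cc1c(O)c(=O)ccn1CC(=O)N/N=C1\C(=O)N(CC(=O)Nc2ccc(Cl)cc2)c2ccccc21` gives 28300 nM in a functional assay on A549 cells (Homo sapiens) for cytotoxicity, read by MTT assay, with a stated time of 48 h; on this read-out lower numbers stand for an effect already at smaller amounts and higher numbers for an effect only at larger amounts of compound. Compound 2 `Cc1c(O)c(=O)ccn1CC(=O)N/N=C1\C(=O)N(CC(=O)Nc2ccccc2)c2ccccc21` gives 29200 nM in this assay, and the step of a 1.0-fold higher number from compound 1 to compound 2 (0.01 log units; within the scatter). Compound 3 `Cc1c(O)c(=O)ccn1CC(=O)N/N=C1\C(=O)N(CC(=O)Nc2ccccc2Cl)c2ccccc21` gives only a limit in this assay, > 100000 nM. The step of an at least 3.5-fold higher number from compound 1 to compound 3 (0.54 log units; beyond the scatter) and the step of an at least 3.4-fold higher number from compound 2 to compound 3 (0.53 log units; beyond the scatter) both place compound 3 at the weak end of the three, sitting at the limit (the limit of > 100000 nM in this assay, at which 1 of the 3 values shown sits).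

Compound 4 `Cc1cccc(NC(=O)CN2C(=O)/C(=N\NC(=O)Cn3ccc(=O)c(O)c3C)c3ccccc32)c1C` differs from compound 3 by 2,3-dimethylphenyl in place of 2-chlorophenyl on an amide-type nitrogen. Among the compounds with values here, no measured step carries a 2,3-dimethylphenyl group on this amide-type nitrogen. Within the data shown here, the steps that bear on the change are the two into compound 3, an at least 3.5-fold higher number from compound 1 to compound 3 (0.54 log units; beyond the scatter) and an at least 3.4-fold higher number from compound 2 to compound 3 (0.53 log units; beyond the scatter), which show that exchanging phenyl or 4-chlorophenyl for 2-chlorophenyl on this nitrogen weakens the effect by a modest amount. Compound 4 again carries a phenyl that is substituted, now as 2,3-dimethylphenyl, so a number close to that of compound 3 is expected, with no step beyond the scatter, a step that the limit leaves unreadable from compound 3 to compound 4. Compound 4 is therefore estimated at 110000 nM, within 35000 nM to 350000 nM, and this assay may well report only a limit again.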

Compound 4, half-maximal effective concentration: 39200 nM
Compound 4: middle estimate off by 2.8-fold (0.45 log units), on the high side; the measured number falls inside the stated range.
By their numbers in this assay, from the lowest: compounds 1, 2 and 4 (each within the scatter of the next). At a limit, above all of these: compound 3.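

A substituted phenyl on this amide-type nitrogen does not by itself shift the number in this assay: the step of a 1.3-fold higher number from compound 2 to compound 4 (0.13 log units; within the scatter) and the step of a 1.4-fold higher number from compound 1 to compound 4 (0.14 log units; within the scatter) place the 2,3-dimethylphenyl group with phenyl and 4-chlorophenyl. Against the 2-chlorophenyl group the picture differs, with the step of an at least 2.5-fold lower number from compound 3 to compound 4 (0.40 log units; beyond the scatter), so among the four groups shown the weak result belongs to 2-chlorophenyl alone and not to substitution on this phenyl as such. Compound 3 remains a limit, so the full size of that step stays unknown: the limit of > 100000 nM in this assay, at which 1 of the 4 values shown sits.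

As far as these compounds go, all four groups on this nitrogen are six-membered aromatic rings of carbon only, so it remains open whether a pyridyl ring, a benzyl group or a plain ethyl chain would keep a number in this range. Also open, from the compounds shown here alone, is whether 2-methylphenyl or 2-fluorophenyl would follow 2-chlorophenyl or 2,3-dimethylphenyl, which would help show how narrowly the weak result is tied to the chloro group.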